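Open-chain hydroxypropyl amides: methyl for methoxy

This account rests on a few compounds, and the source may have more. Where it says the series, first, only, none or still open, it means among the compounds named here.

Measured so far:
compound 1, `O=C1CCC2(c3ccc(F)cc3)OCCCN12`: 68.7 mg/kg
compound 2, `O=C(CCC(=O)c1ccc(Cl)c(Cl)c1)NCCCO`: 450 mg/kg
compound 3, `COc1ccc(C(=O)CCC(=O)NCCCO)cc1`: > 600 mg/kg

In a functional assay on the whole organism with Mus musculus as the target, in the maximal electroshock model (on this read-out lower numbers stand for an effect already at smaller amounts and higher numbers for an effect only at larger amounts of compound), compound 1 gives 68.7 mg/kg and compound 2 gives 450 mg/kg. For the measured compounds named here, for compound 3 the assay reports only a limit, > 600 mg/kg; this is the limit of the assay and not a number, so compound 3 stands at the weak end of the values shown, with no step from it to any other compound measured. The one limit among the three values is that of compound 3 (the limit of > 600 mg/kg in this assay, at which 1 of the 3 values shown sits).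

Compound 4, `Cc1ccc(C(=O)CCC(=O)NCCCO)cc1`, keeps the open chain and the carbonyl pattern of compound 3 and differs in one place: methyl in place of methoxy on an aromatic carbon.

Going by the values given here, no step between measured compounds is available, so the size of the change from a methoxy to a methyl on this ring in this assay cannot be read from the data. Compound 2, the other open-chain amide with a number rather than a limit, sits close to the high end of the scale, and compound 3 sits at the limit; the expectation is that compound 4 stays in the same region, with no step beyond the scatter, and that a limit rather than a number is a real possibility.

Compound 4 is therefore estimated at 550 mg/kg, within 300 mg/kg to 1000 mg/kg, which means an expected step of an at least 1.0-fold lower number from compound 3 to compound 4 (0.03 log units; that floor lies within the scatter).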

Compound 4, dose for half-maximal effect: > 300 mg/kg
Compound 4: only a limit was reported; the forecaster's own chance of this, stated with the estimate: 55%; the middle value lies beyond the limit too.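

No step can be read between compound 3 and compound 4 in this assay, since both carry only limits of the assay. Compound 3 has the limit > 600 mg/kg. Compound 4 has the limit > 300 mg/kg. The compounds shown leave open how large the change from methoxy to methyl is on this read-out, and in which direction it goes.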